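Methyl on the Amide Chain and Vero Cell Toxicity

The source may report more compounds than this note shows. Statements on the series, on what has been measured and on what is new or still open speak of the compounds shown alone.

Compound 3 `CC(=O)Nc1ccc(-c2nc3cc(C(F)(F)F)ccc3n2C2CCCCC2)cc1` and compound 1 `CCC(=O)Nc1ccc(-c2nc3cc(C(F)(F)F)ccc3n2C2CCCCC2)cc1` differ in one place: methyl in place of hydrogen on a saturated chain carbon bound to a carbonyl carbon. In an ADME assay on Vero cells (Chlorocebus sabaeus) for cytotoxicity (on this read-out lower numbers stand for higher toxicity in this test and higher numbers for lower toxicity in this test), compound 3 gives 30000 nM. For compound 1 this assay reports only a limit, > 100000 nM. The step of an at least 3.3-fold higher number from compound 3 to compound 1 (0.52 log units; beyond the scatter) is therefore read against (the limit of > 100000 nM in this assay, at which 2 of the 3 values shown sit). Compound 2 `CC(=O)Nc1ccc(-c2nc3ccccc3[nH]2)cc1` carries the same acetamido group on another core; the difference between the two cores is not broken down here. In this assay compound 2 also gives only a limit, > 100000 nM. Compound 4 `CCC(=O)Nc1ccc(-c2nc3ccccc3[nH]2)cc1` is not yet measured; it differs from compound 2 by methyl in place of hydrogen on a saturated chain carbon bound to a carbonyl carbon, the same change at the same place. Compound 4 is expected to give 150000 nM, an expected step that the limit leaves unreadable from compound 2 to compound 4, resting on the direction of an at least 3.3-fold higher number from compound 3 to compound 1 (0.52 log units; beyond the scatter) and most likely reported again as a limit.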

Compound 4, half-maximal cytotoxic concentration: > 100000 nM
Compound 4: a limit, no number (the forecaster's own chance of this, stated with the estimate: 85%); the middle value lies beyond the limit too.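

In this assay, among these compounds, compound 2 and compound 4 both give only a limit, so no step between them can be read: the limit of > 100000 nM in this assay, at which 3 of the 4 values shown sit. As far as these compounds go, whether methyl in place of hydrogen raises the number on the core of compound 2, as it does on the core of compound 3, stays open.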